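Swapping chloro for nitro on a sulfur-linked anilide

The source may report more compounds than this note shows. Statements on the series, on what has been measured and on what is new or still open speak of the compounds shown alone.

Within the data shown here, compound 1 `O=C(Nc1cc(Sc2ncn[nH]2)c(O)c2ccccc12)c1ccc(Cl)cc1` is the only compound here with a definite number: in a functional assay on MDA-MB-231 cells (Homo sapiens) for antiproliferative activity, read by MTT assay, with a stated time of 48 h (a higher number here means a weaker inhibitor, a lower number a stronger inhibitor), compound 1 gives 25700 nM. Compound 2 `O=C(Nc1cc(Sc2nncs2)c(O)c2ccccc12)c1ccc(Cl)cc1` differs only in the ring attached to the sulfur. In this assay compound 2 reaches > 100000 nM, which is a limit of the assay rather than a number. Among the measured compounds shown here, the only measured step is therefore an at least 3.8-fold higher number from compound 1 to compound 2 (0.59 log units; beyond the scatter), and it ends at the limit of > 100000 nM in this assay, at which 1 of the 2 values shown sits. Compound 3 `O=C(Nc1cc(Sc2ncn[nH]2)c(O)c2ccccc12)c1ccc([N+](=O)[O-])cc1` alters a different part of the molecule: nitro in place of chloro on an aromatic carbon. For the measured compounds named here, no measured step touches this part, so nothing among the measured compounds says which way the number should move, or whether it moves at all. For compound 3 the expected step is a 1.0-fold lower number from compound 1 to compound 3 (0.01 log units; within the scatter), within the scatter. Compound 3 is estimated at 25000 nM in this assay, with a likely range from 8000 nM to 80000 nM.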

Compound 3, half-maximal inhibitory concentration: > 100000 nM
Compound 3: no number, only a limit; the forecaster's own chance of this, stated with the estimate: 20%; middle value at least 4.0-fold (0.60 log units) from the limit.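

Until now, only the ring on the sulfur had been seen to move the read-out. This result shows that a second part of compound 1 also matters: in this assay, nitro in place of chloro on the aromatic ring gives an at least 3.8-fold higher number from compound 1 to compound 3 (0.59 log units; beyond the scatter). The value of compound 3 is a limit of the assay and not a number, so the full size of this step cannot be read. Both single changes shown so far, one on each part of compound 1, end at the same limit: the limit of > 100000 nM in this assay, at which 2 of the 3 values shown sit.

From the compounds shown here alone, only chloro and nitro appear at this place, so it stays open how an amine, a methoxy group or a plain hydrogen there would read. Also open, going by these compounds, is whether any group at this place could bring the number below that of compound 1.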